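The compounds below may be only part of what the source reports. "The series", "measured", "known", "first", "only" and "open" are said of these compounds alone.

In a functional assay on A549 cells (Homo sapiens) for cytotoxicity, read by MTT assay, with a stated time of 72 h (on this read-out higher numbers stand for weaker inhibition and lower numbers for stronger inhibition), three compounds have been measured so far. Compound 1 (`CNC(=O)c1cc(Oc2ccc(NC(=O)c3cc(-c4ccc(C(F)(F)F)cc4)ncn3)cc2F)ccn1`) gives > 100000 nM, which is a limit of the assay and not a number. Compound 2 (`CNC(=O)c1cc(Oc2ccc(NC(=O)c3cc(-c4ccc(Cl)cc4)ncn3)cc2)ccn1`) gives > 100000 nM, again a limit. Among the compounds with values here, compound 3 (`CNC(=O)c1cc(Oc2ccc(NC(=O)c3nccc(-c4ccc(OC)cc4)n3)cc2)ccn1`) is the only one with an actual number, at 11100 nM. Compound 1 therefore stands at the limit of > 100000 nM in this assay, at which 2 of the 3 values shown sit, with no number of its own.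

Compound 4 (`CNC(=O)c1cc(Oc2ccc(NC(=O)c3cc(-c4ccccc4)ncn3)cc2F)ccn1`) keeps the core of compound 1 and changes one place: hydrogen in place of trifluoromethyl on an aromatic carbon. This puts hydrogen in place of trifluoromethyl on an aromatic carbon, so that 4-(trifluoromethyl)phenyl becomes phenyl. Within the data shown here, no measured pair shows this change on its own, so the size of the step in this assay has to be judged indirectly. Compound 3, at 11100 nM, shows that a number can be reached among these compounds, but its structure differs from that of compound 1 in more than one place. Only a small move towards stronger inhibition is therefore expected, and compound 4 may well read as a limit again. The expected step, an at least 1.6-fold lower number from compound 1 to compound 4 (0.22 log units; that floor lies within the scatter), is an estimate and a modest one. For compound 4 the estimated value is 60000 nM, with an expected range of 15000 nM to 100000 nM.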

Compound 4, half-maximal inhibitory concentration: 23200 nM
The estimate for compound 4 lay 2.6-fold (0.41 log units) above the measured number; low and high end bracket the measured number.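

In this assay, within the data shown here, the change from 4-(trifluoromethyl)phenyl to phenyl gives the first step that can be read between compounds differing in one place: an at least 4.3-fold lower number from compound 1 to compound 4 (0.63 log units; beyond the scatter). That step has only a floor and no full size, because compound 1 stands at a limit of the assay and not at a number: the limit of > 100000 nM in this assay, at which 2 of the 4 values shown sit. Compound 4 thus shows that a number can be reached with the rest of compound 1 unchanged and hydrogen on this aromatic carbon, which compound 3 could not show, as it differs from compound 1 in more than one place.

The compounds shown leave open how the read-out would respond to other groups on this carbon, such as an amine or a carboxylic acid, since hydrogen against trifluoromethyl is the only comparison available there. They also leave open whether the same change would give a step of similar size on the core of compound 3, and how large the step from compound 1 truly is.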